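The source may hold more compounds than are shown below. What is called first, only, known or untested is meant among the compounds shown, and "the series" means these compounds.

In a functional assay on COLO 205 cells (Homo sapiens) for inhibition, read by sulforhodamine B assay (on this read-out higher numbers stand for weaker inhibition of growth and lower numbers for stronger inhibition of growth), compound 1 `COc1ccc(-c2ccc(-c3ccc(-c4nc5cc(C)ccc5[nH]4)cc3)cc2)cc1OC` gives 2320 nM, compound 2 `COc1cc(-c2ccc(-c3ccc(-c4nc5cc(C)ccc5[nH]4)cc3)cc2)cc(OC)c1OC` gives 190 nM, and compound 3 `FC(F)(F)c1ccc(-c2ccc(-c3ccc(-c4nc5ccccc5[nH]4)cc3)cc2)cc1` gives 33900 nM, the highest number of the three. Compound 4 `Clc1cccc(-c2ccc(-c3ccc(-c4nc5ccccc5[nH]4)cc3)cc2)c1` carries 3-chlorophenyl in place of 4-(trifluoromethyl)phenyl on an aromatic carbon, para to a large group: 3-chlorophenyl in place of 4-(trifluoromethyl)phenyl on an aromatic carbon. Among the compounds with values here, the only measured single-place step, a 12-fold lower number from compound 1 to compound 2 (1.09 log units; beyond the scatter), is large, but it is methoxy in place of hydrogen and so bears only loosely on this change. Within the data shown here, no measured step exchanges these two groups. A moderate move towards stronger inhibition is therefore expected in this assay, an estimated step of a 2.8-fold lower number from compound 3 to compound 4 (0.45 log units; beyond the scatter). Compound 4 is estimated at 12000 nM, with an expected range of 3000 nM to 40000 nM.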

Compound 4, concentration for 50% growth inhibition: 100000 nM
The estimate for compound 4 lay 8.3-fold (0.92 log units) below the measured number; the measured number lies above the stated range.
By their numbers in this assay, from the lowest: compound 2; then compound 1; then compound 3; then compound 4.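

In this assay, 3-chlorophenyl in place of 4-(trifluoromethyl)phenyl gives a 2.9-fold higher number from compound 3 to compound 4 (0.47 log units; beyond the scatter), a move towards weaker inhibition of growth, so this aromatic carbon is not indifferent to which substituted phenyl it carries. Neither group has hydrogen-bond donors, hydrogen-bond acceptors or a net charge, so these counts do not separate the two. No measurement at hand accounts for the direction of this step.

Going by these compounds, how a phenyl carrying an amine or a carboxylic acid would read at this place stays open. Also open, on these data alone, is whether the methoxy step, a 12-fold lower number from compound 1 to compound 2 (1.09 log units; beyond the scatter), holds on the core of compound 3.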